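Indene-acrylamide series: amide nitrogen substituent and in vivo dose

The source may hold more compounds than are shown below. What is called first, only, known or untested is meant among the compounds shown, and "the series" means these compounds.

Measured so far:
compound 1, `NC(=O)/C=C1\CCc2ccc(Cl)cc21`, 27 mg/kg
compound 2, `O=C(/C=C1\CCc2ccc(F)cc21)Nc1ccccc1`, 8 mg/kg

Two compounds of the shared core have been run in a functional assay on the whole organism with Rattus norvegicus as the target; a higher number here means that more compound is needed for the effect, a lower number that less compound is needed. Compound 1 carries the unsubstituted amide and gives 27 mg/kg. Compound 2 carries a phenyl on the amide nitrogen, with fluorine in place of chlorine on the core, and gives 8 mg/kg. Compound 2 thus stands at the lower of the two numbers, and its gap to compound 1 lies beyond the usual scatter; since the two compounds differ in two places at once, no single change can be read from that gap.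

The next compound, compound 3, `O=C(/C=C1\CCc2ccc(F)cc21)NCc1ccccc1`, keeps the core of compound 2 and alters only the amide substituent: benzyl in place of phenyl on an amide-type nitrogen. Within the data shown here, no pair of measured compounds carries this change, so there is nothing in this assay to set its size or direction. The amide nitrogen still bears one aromatic ring, and a step of modest size in either direction, or none beyond the scatter, is the plainest expectation; a slight rise in dose is taken as the middle case, as the one substituted amide measured, compound 2, gives 8 mg/kg with the ring attached directly.

Compound 3 is therefore expected to give about 12 mg/kg, within a range of 4 mg/kg to 36 mg/kg, which means an estimated step of a 1.5-fold higher number from compound 2 to compound 3 (0.18 log units; within the scatter).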

Compound 3, dose for half-maximal effect: 16 mg/kg
The estimate for compound 3 lay 1.3-fold (0.12 log units) below the measured number, within the range that was stated.
By their numbers in this assay, from the lowest: compounds 2, 3 and 1 (each within the scatter of the next, the first and the last beyond it).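

Among these compounds, compound 2 and compound 3 form the first pair that differs in one place only, so the amide nitrogen substituent can now be read on its own in this assay, where the change of phenyl to benzyl gives a 2.0-fold higher number from compound 2 to compound 3 (0.30 log units; within the scatter) and does not separate the two compounds. On this core, an amide-type nitrogen therefore carries either group without a difference that can be told from the scatter, and the dose stays in the same range with the aromatic ring kept on a phenyl or a benzyl substituent. Nothing available bears on the reason for this result.

Compound 1 differs from compound 2 and from compound 3 in two places, so the steps to it cannot be read, and the unsubstituted amide remains unseparated from the exchange of chlorine for fluorine on the core. Also open, going by these compounds, is how the dose responds at this nitrogen to a longer chain such as phenethyl, or to a group of a different kind such as a carboxylic acid or an amine on that chain.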